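Methoxy in place of methyl, on two related cores

The source may hold more compounds than are shown below. What is called first, only, known or untested is meant among the compounds shown, and "the series" means these compounds.

Compound 1 `Cc1cccc2c(NCc3ccco3)nc(NC(C)C)nc12` and compound 2 `Cc1ccc2nc(NC(C)C)nc(NCc3ccco3)c2c1` have the same atoms joined differently; how the two cores differ is not broken down here. In a physicochemical assay for permeability, using PAMPA, at pH 4 (on this read-out higher numbers stand for higher permeability and lower numbers for lower permeability), compound 1 gives 45.9 10^-6 cm/s. In this assay compound 2 gives 67.2 10^-6 cm/s, and the two values lie within the scatter of each other. Compound 3 `COc1cccc2c(NCc3ccco3)nc(NC(C)C)nc12` differs from compound 1 by methoxy in place of methyl on an aromatic carbon. In this assay compound 3 gives 38.4 10^-6 cm/s.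

Compound 4 `COc1ccc2nc(NC(C)C)nc(NCc3ccco3)c2c1` differs from compound 2 by methoxy in place of methyl on an aromatic carbon. The place is not the same word for word: in compound 3 the methoxy sits ortho to a fused ring and meta to a fused ring, in compound 4 meta to a fused ring and para to a fused ring, so the two are the same kind of change, not the same change. Among the four compounds the change occurs twice in all, and its one measured step, a 1.2-fold lower number from compound 1 to compound 3 (0.08 log units; within the scatter), is within the scatter.

In this assay the expected step is a 1.2-fold lower number from compound 2 to compound 4 (0.08 log units; within the scatter), set beside the measured one, and it rests on compound 2 at 67.2 10^-6 cm/s together with the small measured step for the same kind of change. Compound 4 is therefore estimated at 56 10^-6 cm/s in this assay. The estimated range for compound 4 runs from 32 10^-6 cm/s to 100 10^-6 cm/s.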

Compound 4, apparent permeability: 80.2 10^-6 cm/s
Estimate against measurement, compound 4: 1.4-fold (0.16 log units) below, and the stated range covers the measured number.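

Carried to the second core, methoxy in place of methyl gives in this assay a step of a 1.2-fold higher number from compound 2 to compound 4 (0.08 log units; within the scatter) and, on the core of compound 1, the earlier step was a 1.2-fold lower number from compound 1 to compound 3 (0.08 log units; within the scatter) and so, with both steps printed as within the scatter, neither core shows a difference that repeat measurements could separate from noise. This supports only a narrow statement: across these two pairs the change has left the read-out within the usual spread on both cores, while the opposite signs of the two steps carry no meaning, and two pairs with the methoxy at different places on the ring do not establish a rule for the series or show that a larger step on one core would reappear on the other. No measurement is at hand that explains the read-out for any of these compounds.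

The compounds shown keep to methyl and methoxy on this ring, so it remains open whether a larger change at these places, such as an amine, a carboxylic acid or a longer chain like butoxy, would give a step beyond the scatter. Going by these compounds, it also remains open whether any such step would carry from one core to the other.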